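A few compounds are considered here, and "the series" means these few. Any claim that something is new, unique, unknown or untested is made for them only; others in the source may bear on it.

Working notes on the series, read in a physicochemical assay for lipophilicity, at pH 7.4; a higher number here means a more lipophilic compound, a lower number a more polar compound. Compound 1 `COc1ccc2c(c1)C=CN(C)C(=O)[C@@H]2C` gives 4.3, compound 2 `COCCOc1ccc2c(c1)C=CN(C)C(=O)[C@@H]2C` gives 4, and compound 3 `C[C@H]1C(=O)N(C)C=Cc2cc(OC(CO)CO)ccc21` gives 1.3, the lowest of the three numbers. The next structure is compound 4 `C[C@H]1C(=O)N(C)C=Cc2cc(CC3CCOCC3)ccc21`, and the change is (oxan-4-yl)methyl in place of 2-hydroxy-1-(hydroxymethyl)ethoxy on an aromatic carbon. Among the measured compounds shown here, no measured step covers this exchange directly. The nearest evidence is a number 3.00 log units lower from compound 1 to compound 3 (beyond the scatter) and a number 2.70 log units lower from compound 2 to compound 3 (beyond the scatter), both large and beyond the scatter, while a number 0.30 log units lower from compound 1 to compound 2 (within the scatter) stays within it. Read in reverse, these steps suggest that losing the 2-hydroxy-1-(hydroxymethyl)ethoxy group should give a large upward step in this assay. For the measured compounds named here, no measured compound carries a carbon-linked group at this aromatic carbon, so the range is kept wide. The estimated step is a number 2.70 log units higher from compound 3 to compound 4 (beyond the scatter). For compound 4 the estimated value is 4, with an expected range from 3.5 to 4.5.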

Compound 4, distribution coefficient: 5.4
Beside the measured number, compound 4's estimate is 1.40 log units below it; the whole stated range lies below it.
By their numbers in this assay, from the lowest: compound 3; then compounds 2 and 1 (each within the scatter of the next); then compound 4.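

In this assay the carbon-linked (oxan-4-yl)methyl group on this aromatic carbon gives the highest number of the four compounds, with a number 4.10 log units higher from compound 3 to compound 4 (beyond the scatter) and a number 1.40 log units higher from compound 2 to compound 4 (beyond the scatter) and a number 1.10 log units higher from compound 1 to compound 4 (beyond the scatter) as its steps. Methoxy and 2-methoxyethoxy stand within the scatter of each other, so the two oxygen-linked ethers did not show how far the number can move upward at this position, and this exchange does. Nothing measured on these compounds accounts for the size of these steps.

The compounds shown leave open whether the rise follows the carbon link or the six-membered non-aromatic ring, as compound 4 brings in both at once. A group with the same ring held on an oxygen would separate the two.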